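Azepan-1-yl to 4-methylpiperazin-1-yl in compound 3

A few compounds are considered here, and "the series" means these few. Any claim that something is new, unique, unknown or untested is made for them only; others in the source may bear on it.

compound 1 `CCCCCCCCCCOP(=O)(O)OCCSC(=S)N1CCCCCC1` gives 43300 nM
compound 2 `CCCCCCCCCCOP(=O)(O)OCCSC(=S)N1CCN(C)CC1` gives 99600 nM
compound 3 `CCCCCCOP(=O)(O)OCCSC(=S)N1CCCCCC1` gives 55000 nM

All three numbers come from a functional assay on MCF7 cells (Homo sapiens) for inhibition, read by MTT assay, with stated times of 18 h and 4 h; on this read-out higher numbers stand for weaker inhibition and lower numbers for stronger inhibition. Compound 3, at 55000 nM, lies within the usual scatter of both compound 1 and compound 2, although those two are separated by more than the scatter. The open question is compound 4 `CCCCCCOP(=O)(O)OCCSC(=S)N1CCN(C)CC1`, which differs from compound 3 in one place, with 4-methylpiperazin-1-yl in place of azepan-1-yl on a thiocarbonyl carbon.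

The same exchange has been measured once, as a 2.3-fold higher number from compound 1 to compound 2 (0.36 log units; beyond the scatter), a modest step just beyond the scatter. The other measured step, a 1.3-fold higher number from compound 1 to compound 3 (0.10 log units; within the scatter), lies on the chain and stays within the scatter. It gives no sign that the exchange should behave differently on the shorter chain, yet a single pair is thin support. The expected step in this assay is therefore a 2.3-fold higher number from compound 3 to compound 4 (0.36 log units; beyond the scatter), of similar size and toward a higher number. For compound 4 the estimate is 125000 nM, with an expected range from 70000 nM to 220000 nM, and the measurement will show whether the step carries over.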

Compound 4, half-maximal inhibitory concentration: 58000 nM
Compound 4: the middle estimate sits 2.2-fold (0.33 log units) above what was measured, and the stated range ends above it.
By their numbers in this assay, from the lowest: compounds 1, 3, 4 and 2 (each within the scatter of the next, the first and the last beyond it).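

On the shorter chain of compound 3, putting 4-methylpiperazin-1-yl in place of azepan-1-yl on the thiocarbonyl carbon gives a 1.1-fold higher number from compound 3 to compound 4 (0.02 log units; within the scatter) in this assay, so the step beyond the scatter seen on the longer chain does not recur here. Read across both pairs, the exchange has no firm size in this assay, and the two readings cannot be told apart as a real dependence on the chain: the same change on two cores in this assay, a 2.3-fold higher number (0.36 log units; beyond the scatter) from compound 1 to compound 2 and a 1.1-fold higher number (0.02 log units; within the scatter) from compound 3 to compound 4, 2.2-fold (0.34 log units) apart, within the scatter of two such steps. The chain change, now also read with 4-methylpiperazin-1-yl in place, gives a 1.7-fold lower number from compound 2 to compound 4 (0.23 log units; within the scatter), so it stays within the scatter on both thiocarbonyl substituents, and these compounds show no clear effect of chain length at this level of inhibition: the same change on two cores in this assay, a 1.3-fold higher number (0.10 log units; within the scatter) from compound 1 to compound 3 and a 1.7-fold lower number (0.23 log units; within the scatter) from compound 2 to compound 4, 2.2-fold (0.34 log units) apart, within the scatter of two such steps.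

The compounds shown leave open whether the single step beyond the scatter, between compound 1 and compound 2, reflects a true difference or only the spread of the measurements. They also leave open whether another amine on the thiocarbonyl carbon, such as morpholin-4-yl or an open-chain diethylamino group, or a chain longer than that of compound 1, would move the number clearly beyond the scatter.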